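Notes on the step from compound 3 to compound 4

A few compounds are considered here, and "the series" means these few. Any claim that something is new, unique, unknown or untested is made for them only; others in the source may bear on it.

Measured so far in a physicochemical assay for lipophilicity, at pH 7.4; on this read-out higher numbers stand for higher lipophilicity and lower numbers for lower lipophilicity:
- compound 1 `Cc1c2c(nn1-c1nnc(-c3ccc(OC(C)C)c(C#N)c3)s1)CCN(CCC(=O)O)C2`: 2.76
- compound 2 `CC(C)Oc1ccc(-c2nnc(-n3cc4c(n3)CCN(CCCC(=O)O)C4)s2)cc1Cl`: 3.56
- compound 3 `CC(C)Oc1ccc(-c2nnc(-n3cc4c(n3)CCN(CCC(=O)O)C4)s2)cc1C#N`: 2.58

Compound 3 at 2.58 lies within the scatter of compound 1 at 2.76, and both lie clearly under compound 2 at 3.56.

The next compound is compound 4 `CC(C)Oc1ccc(-c2nnc(-n3cc4c(n3)CCN(CCCC(=O)O)C4)s2)cc1C#N`. Its difference from compound 3 is carboxymethyl in place of carboxy on a saturated chain carbon, two bonds along the chain from an amine nitrogen in a ring. Cut one bond further out, the same change reads 2-carboxyethyl to 3-carboxypropyl.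

Within the data shown here, only one measured step links two compounds that differ in a single place: a number 0.18 log units lower from compound 1 to compound 3 (within the scatter). Among the measured compounds shown here, that change lies elsewhere on the structure, so it says nothing direct about the chain, and it shows only that a single-place change can stay within the scatter here. For the measured compounds named here, compound 2, at 3.56, is the only measured compound with the 3-carboxypropyl chain, but no single-place step connects it to compound 3. Its value therefore serves as a loose upper guide and does not measure the chain change.

In this assay a modest rise is expected, estimated as a number 0.37 log units higher from compound 3 to compound 4 (beyond the scatter). The estimate for compound 4 is 2.95, with an expected range from 2.6 to 3.3.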

Compound 4, distribution coefficient: 2.87
Beside the measured number, compound 4's estimate is 0.08 log units above it; low and high end bracket the measured number.
By their numbers in this assay, from the lowest: compounds 3, 1 and 4 (each within the scatter of the next); then compound 2.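

In this assay the change from 2-carboxyethyl to 3-carboxypropyl, on a saturated chain carbon, two bonds along the chain from an amine nitrogen in a ring, gives a number 0.29 log units higher from compound 3 to compound 4 (within the scatter) as its first direct reading, so this single extension does not separate the two compounds on this read-out. With the 3-carboxypropyl chain held constant, cyano in place of chloro on an aromatic carbon can now also be read directly: it gives a number 0.69 log units lower from compound 2 to compound 4 (beyond the scatter) and, of the two new steps, only this one lies beyond the scatter. No measurement at hand accounts for either step.

Going by these compounds, how a shorter carboxymethyl chain or a longer 4-carboxybutyl chain would read on this scale remains open, as does the effect of a primary amide in place of the carboxylic acid. Also open, on these data alone, is whether the cyano-for-chloro step keeps its size on the 2-carboxyethyl chain, and whether other aromatic groups, such as trifluoromethyl, follow either of the two compounds in that place.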